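The compounds below may be only part of what the source reports. "The series", "measured", "known", "first", "only" and "open" are said of these compounds alone.

In a functional assay for activation of Alpha-1A adrenergic receptor (Homo sapiens), read by calcium flux (on this read-out higher numbers stand for an effect only at larger amounts of compound and lower numbers for an effect already at smaller amounts), compound 3 `c1csc(-c2ccccc2OCC2=NCCN2)c1` gives 1 nM, the lowest of the two numbers measured. Compound 1 `c1cncc(-c2ccccc2OCC2=NCCN2)c1` gives 2 nM, and a 2.0-fold lower number from compound 1 to compound 3 (0.30 log units; within the scatter) stays within the scatter. For compound 2 `c1ccc(-c2ccncc2)c(OCC2=NCCN2)c1` the assay reports only a limit, < 100000 nM. Owing to the limit of < 100000 nM in this assay, at which 1 of the 3 values shown sits, both a step that the limit leaves unreadable from compound 1 to compound 2 and a step that the limit leaves unreadable from compound 2 to compound 3 remain unreadable in size. Compound 4 `c1ccc(-c2cc[nH]n2)c(OCC2=NCCN2)c1` differs from compound 3 by 1H-pyrazol-3-yl in place of thiophen-2-yl on an aromatic carbon. Going by the values given here, the only readable step, pyridin-3-yl against thiophen-2-yl, was small, while the unreadable steps show that a change of the ring on that carbon can remove the effect altogether. A modest rise in number is expected, a 10-fold higher number from compound 3 to compound 4 (1.00 log units; beyond the scatter), with a wide margin. Compound 4 is therefore estimated to give 10 nM, between 1 nM and 300 nM.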

Compound 4, half-maximal effective concentration: 5.01 nM
Estimate against measurement, compound 4: 2.0-fold (0.30 log units) above, and the stated range covers the measured number.
By their numbers in this assay, from the lowest: compounds 3 and 1 (each within the scatter of the next); then compound 4.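

At this aromatic carbon, 1H-pyrazol-3-yl, which carries a hydrogen-bond donor that thiophen-2-yl lacks, retains the effect in this assay, with a 5.0-fold higher number from compound 3 to compound 4 (0.70 log units; beyond the scatter) and a 2.5-fold higher number from compound 1 to compound 4 (0.40 log units; beyond the scatter). Going by these compounds alone, these are the first readable steps at this position beyond the scatter, so a change of ring here can also shift the number modestly, not only leave it in place or remove the effect. The steps to and from compound 2 cannot be read: the limit of < 100000 nM in this assay, at which 1 of the 4 values shown sits.

Open, as far as these compounds go, is whether 1-methyl-1H-pyrazol-3-yl would give a number close to that of compound 4. Also open, from the compounds shown here alone, is whether an amine or a carboxylic acid on this carbon would retain the effect.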